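A few compounds are considered here, and "the series" means these few. Any claim that something is new, unique, unknown or untested is made for them only; others in the source may bear on it.

Series so far, in a functional assay on NCI-H460 cells (Homo sapiens) for antiproliferative activity, with a stated time of 72 h; on this read-out higher numbers stand for weaker inhibition and lower numbers for stronger inhibition:
- compound 1 `Nc1ncnn2c([C@@H]3O[C@H](CO)[C@@H](O)[C@H]3O)cc(C#Cc3ccccc3)c12`: 38500 nM
- compound 2 `COc1ccc(-c2cc([C@@H]3O[C@H](CO)[C@@H](O)[C@H]3O)n3ncnc(N)c23)cc1`: 69300 nM
- compound 3 `Nc1ncnn2c([C@@H]3O[C@H](CO)[C@@H](O)[C@H]3O)cc(/C=C/c3ccccc3)c12`: 3700 nM

Compound 3 has the lowest number of the three, and both gaps to it lie beyond the scatter: a 10-fold lower number from compound 1 to compound 3 (1.02 log units; beyond the scatter) and a 19-fold lower number from compound 2 to compound 3 (1.27 log units; beyond the scatter). The other pair does not separate, with a 1.8-fold higher number from compound 1 to compound 2 (0.26 log units; within the scatter).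

Next is compound 4 `Nc1ncnn2c([C@@H]3O[C@H](CO)[C@@H](O)[C@H]3O)cc(-c3ccsc3)c12`, with thiophen-3-yl in place of 2-phenylethenyl on an aromatic carbon of the shared core: thiophen-3-yl in place of 2-phenylethenyl on an aromatic carbon.

The closest evidence is the step between compound 2 and compound 3, a 19-fold lower number from compound 2 to compound 3 (1.27 log units; beyond the scatter), since compound 2 also carries an aromatic ring at this place with no double bond outside it. Read backwards, that step points to a higher number for compound 4. Among the measured compounds shown here, compound 1 also sits well above compound 3, with a 10-fold lower number from compound 1 to compound 3 (1.02 log units; beyond the scatter), so 2-phenylethenyl is the only group here with a low number. However, thiophen-3-yl has not been tested in this series, and the 4-methoxyphenyl of compound 2 is only a loose guide to it. Only part of that large step is therefore carried over.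

In this assay, the expected change is a 3.2-fold higher number from compound 3 to compound 4 (0.51 log units; beyond the scatter), a rise of moderate size with wide uncertainty. For compound 4 the estimated value is 12000 nM, with an expected range of 1500 nM to 70000 nM.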

Compound 4, half-maximal inhibitory concentration: 35600 nM
The estimate for compound 4 lay 3.0-fold (0.47 log units) below the measured number; the range from low to high includes it.
By their numbers in this assay, from the lowest: compound 3; then compounds 4, 1 and 2 (each within the scatter of the next).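

In this assay, replacing 2-phenylethenyl with thiophen-3-yl at this aromatic carbon of the shared core does not keep the low number of compound 3, with a 9.6-fold higher number from compound 3 to compound 4 (0.98 log units; beyond the scatter). Compound 4 does not separate from the other two compounds, with a 1.9-fold lower number from compound 2 to compound 4 (0.29 log units; within the scatter) and a 1.1-fold lower number from compound 1 to compound 4 (0.03 log units; within the scatter), so thiophen-3-yl, 4-methoxyphenyl and 2-phenylethynyl cannot be ranked here. Compound 3 is now the only one of the four set apart beyond the scatter, and a five-membered aromatic ring with a sulfur atom placed directly on the core gives no gain over the six-membered rings of compounds 1 and 2; no measurement at hand accounts for this difference.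

The compounds shown leave open whether the low number of compound 3 depends on the double bond outside aromatic rings, a question that a 2-phenylethyl chain at the same carbon would address. Also open, as far as these compounds go, is how far the aromatic ring at the end of the 2-phenylethenyl group can change, for example through a thiophen-3-yl ring or an amine carried on the double bond in its place.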